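A few compounds are considered here, and "the series" means these few. Any claim that something is new, unique, unknown or untested is made for them only; others in the source may bear on it.

Compound 1 `COc1ccc2c(=O)c(/C=C/C(=O)Nc3ccccc3)coc2c1` and compound 2 `COc1ccc2c(=O)c(/C=C/C(=O)NCc3ccc(C)cc3)coc2c1` share one core and differ only in the group on the amide-type nitrogen. In a functional assay on A549 cells (Homo sapiens) for inhibition, read by MTT assay, with a stated time of 48 h (a higher number here means a weaker inhibitor, a lower number a stronger inhibitor), compound 1 gives 51000 nM. Compound 2 reaches only the limit of this assay, > 100000 nM, so its standing is known as a bound and not as a number. The step of an at least 1.9-fold higher number from compound 1 to compound 2 (0.29 log units; that floor lies within the scatter) therefore rests on that bound, as set out in the limit of > 100000 nM in this assay, at which 1 of the 2 values shown sits. Compound 3 `CCOc1ccc(NC(=O)/C=C/c2coc3cc(OC)ccc3c2=O)cc1` has not yet been measured. It differs from compound 2 in that (4-ethoxyphenyl in place of 4-methylbenzyl on an amide-type nitrogen), which once more places a six-membered aromatic ring of carbon only directly on the nitrogen, as in compound 1. For the measured compounds named here, the only measured step that bears on this change is an at least 1.9-fold higher number from compound 1 to compound 2 (0.29 log units; that floor lies within the scatter), which ran in the opposite direction and whose size lies at the floor of the limit. For compound 3 the expected step is an at least 1.6-fold lower number from compound 2 to compound 3 (0.22 log units; that floor lies within the scatter), toward a lower number, back in the neighbourhood of compound 1. The estimate for compound 3 in this assay is 60000 nM, with a range from 20000 nM to 180000 nM.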

Compound 3, half-maximal inhibitory concentration: > 100000 nM
Compound 3: a limit, no number (the forecaster's own chance of this, stated with the estimate: 35%); middle value at least 1.6-fold (0.22 log units) from the limit.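

In this assay compound 3 also stops at a limit, > 100000 nM, which is a bound and not a number. Placing a six-membered aromatic ring of carbon directly on the amide-type nitrogen is therefore not enough on its own to yield a measured value: compound 3 has this feature, as compound 1 does, yet only compound 1 has a number, and adding ethoxy in place of hydrogen on an aromatic carbon gives an at least 1.9-fold higher number from compound 1 to compound 3 (0.29 log units; that floor lies within the scatter). The step between compound 2 and compound 3 cannot be read, so 4-ethoxyphenyl and 4-methylbenzyl on that nitrogen cannot be ranked, and most of the series now rests on a bound: the limit of > 100000 nM in this assay, at which 2 of the 3 values shown sit.

The compounds shown leave open where compound 2 and compound 3 truly stand, and whether the ethoxy step reaches beyond the scatter at all. They also leave open whether an amine or a carboxylic acid in place of ethoxy on that aromatic carbon would give a value that can be read against compound 1.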